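A Carbamoyl Group Replaces Ethyl on the Longer Chain

This account rests on a few compounds, and the source may have more. Where it says the series, first, only, none or still open, it means among the compounds named here.

In a functional assay on PANC-1 cells (Homo sapiens) for inhibition, read by MTT assay, with a stated time of 24 h (a higher number here means a weaker inhibitor, a lower number a stronger inhibitor), compound 1 `CCOc1cc(=O)n(CCCO)c2c1CC(CC=C(C)C)C(C)(C)C2` gives 7300 nM, compound 2 `CC(C)=CCC1Cc2c(OC(=O)Nc3ccc(F)c(F)c3)cc(=O)n(CCCO)c2CC1(C)C` gives 7300 nM and compound 3 `CCOc1cc(=O)n(CCCO)c2c1CC(C/C=C(\C)CCC=C(C)C)C(C)(C)C2` gives 5800 nM. Compound 3 thus stands within the scatter of both other compounds, and the three numbers set no order among them.

Compound 4 `COc1ccc(NC(=O)Oc2cc(=O)n(CCCO)c3c2CC(C/C=C(\C)CCC=C(C)C)C(C)(C)C3)cc1` differs from compound 3 in one place: (4-methoxyphenyl)carbamoyl in place of ethyl on an oxygen on an aromatic ring. In words, a (4-methoxyphenyl)carbamoyl group stands in place of ethyl on an oxygen on an aromatic ring.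

For the measured compounds named here, two measured steps bear on this change. The closer precedent is no change at the digits printed from compound 1 to compound 2 (within the scatter), which is the same kind of exchange on that oxygen, although it involves a different carbamoyl group and lacks the added 3-methylbut-2-en-1-yl. The other is a 1.3-fold lower number from compound 1 to compound 3 (0.10 log units; within the scatter), which adds that group to the chain and so shows the change already present in compound 3. Neither step leaves the scatter. Going by the values given here, no measured compound yet carries both changes together, so the data do not show how they combine.

No step beyond the scatter is therefore expected in this assay. The expected step is a 1.1-fold lower number from compound 3 to compound 4 (0.02 log units; within the scatter), which is estimated to remain within the scatter. Compound 4 is estimated at 5500 nM, with an expected range from 2500 nM to 11000 nM.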

Compound 4, half-maximal inhibitory concentration: 7100 nM
Compound 4: the middle estimate sits 1.3-fold (0.11 log units) below what was measured; low and high end bracket the measured number.
By their numbers in this assay, from the lowest: compounds 3, 4, 1 and 2 (each within the scatter of the next).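

In this assay the step of a 1.2-fold higher number from compound 3 to compound 4 (0.09 log units; within the scatter) shows that this exchange on the oxygen also stays within the scatter when the core carries the chain of compound 3, and with a carbamoyl group bearing a methoxy-substituted phenyl ring. Read with the step of no change at the digits printed from compound 1 to compound 2 (within the scatter), it shows that neither (3,4-difluorophenyl)carbamoyl nor (4-methoxyphenyl)carbamoyl, each bringing an aromatic ring and a hydrogen-bond donor in place of ethyl, moves the number beyond the scatter, each on its own chain. No available evidence accounts for this result.

As far as these compounds go, whether a phenyl ring carrying an amine or a carboxylic acid, or a carbamoyl group with no aromatic ring, would give a step beyond the scatter on this oxygen stays open. From the compounds shown here alone, all four compounds also keep the hydroxyl group of the 3-hydroxypropyl chain, so it remains equally open whether an amine or a carboxylic acid in its place would change the number in this assay at all.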